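The compounds below may be only part of what the source reports. "The series", "measured", "known", "first", "only" and "open" are said of these compounds alone.

Three compounds share one core and differ only in the group on a six-membered aromatic ring of carbon only. Compound 1 `CC(C)c1ccc(NC(=O)c2csc(Cc3c(Cl)cccc3Cl)n2)cc1` gives 370 nM in an assay on CHO cells, read by calcium flux; a higher number here means a weaker inhibitor, a lower number a stronger inhibitor. Compound 2 `CCc1ccc(NC(=O)c2csc(Cc3c(Cl)cccc3Cl)n2)cc1` gives 810 nM in this assay, and compound 3 `N#Cc1ccc(NC(=O)c2csc(Cc3c(Cl)cccc3Cl)n2)cc1` gives 450 nM. Compound 3 thus stands within the scatter of both compound 1 and compound 2, so no real separation is shown. Compound 4 `O=C(Nc1ccc(C(F)(F)C(F)(F)F)cc1)c1csc(Cc2c(Cl)cccc2Cl)n1` carries the change (1,1,2,2,2-pentafluoroethyl in place of cyano on an aromatic carbon). Among the compounds with values here, the steps that bear on it, a 1.2-fold higher number from compound 1 to compound 3 (0.09 log units; within the scatter) and a 1.8-fold lower number from compound 2 to compound 3 (0.26 log units; within the scatter), show that exchanging the group at this place has so far moved the number little, and even a 2.2-fold higher number from compound 1 to compound 2 (0.34 log units; beyond the scatter) was modest. A step of a 1.1-fold lower number from compound 3 to compound 4 (0.05 log units; within the scatter) is therefore expected, not clearly beyond the scatter. Compound 4 is estimated at 400 nM, between 150 nM and 1100 nM.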

Compound 4, half-maximal inhibitory concentration: 290 nM
Beside the measured number, compound 4's estimate is 1.4-fold (0.14 log units) above it; the measured number falls inside the stated range.
By their numbers in this assay, from the lowest: compounds 4, 1, 3 and 2 (each within the scatter of the next, the first and the last beyond it).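

In this assay the 1,1,2,2,2-pentafluoroethyl group, with 7 heavy atoms, gives a 1.6-fold lower number from compound 3 to compound 4 (0.19 log units; within the scatter) against cyano and a 1.3-fold lower number from compound 1 to compound 4 (0.11 log units; within the scatter) against isopropyl, so this place takes a much larger group with no real shift in the number. Against ethyl it gives a 2.8-fold lower number from compound 2 to compound 4 (0.45 log units; beyond the scatter) and that is its only step that clears the scatter. No measurement shown here explains these numbers. Still open, going by these compounds, is whether an amine, a carboxylic acid or a longer fluorinated chain at this place would stay in the same range.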